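Chloro to methoxy, tried a second time

This account rests on a few compounds, and the source may have more. Where it says the series, first, only, none or still open, it means among the compounds named here.

Measured so far:
Compound 1 `O=C(O)c1cnc(-c2ccc(Cl)cc2)[nH]c1=O` gives 5 mg/kg in a functional assay on the whole organism (strain Sprague-Dawley) for inhibition, with Rattus norvegicus as the target, with a stated time of 10 min; a higher number here means that more compound is needed for the effect, a lower number that less compound is needed.
Compound 2 `COc1ccc(-c2ncc(C(=O)O)c(=O)[nH]2)cc1` gives only a limit of this assay, > 5 mg/kg.
Compound 3 `CCOc1ccc(Cl)cc1-c1ncc(C(=O)O)c(=O)[nH]1` gives 0.5 mg/kg in this assay.

Compound 3 stands lowest of the two numbers; compound 1 sits a clear distance higher, beyond the usual scatter. The difference between the core of compound 1 and the core of compound 3 is not broken down here.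

Between compound 1 and compound 2 one change is made (methoxy in place of chloro on an aromatic carbon), and the step it made is a number no lower from compound 1 to compound 2 (the limit leaves the size open). The value of compound 2 is a limit, with the limit of > 5 mg/kg in this assay, at which 1 of the 3 values shown sits, so only a direction, not a size, can be read from this pair.

Compound 4 `CCOc1ccc(OC)cc1-c1ncc(C(=O)O)c(=O)[nH]1` is not yet measured. It differs from compound 3 by the same kind of change (methoxy in place of chloro on an aromatic carbon), but the surroundings are not the same: here the group sits meta to a large group and para to an ethoxy group, whereas in the earlier pair it sat para to a large group.

Compound 4 is expected to need more compound than compound 3, because the earlier instance of this change gave a number no lower from compound 1 to compound 2 (the limit leaves the size open), a step that did not lower the number. The step from compound 3 to compound 4 is estimated at a 4.0-fold higher number from compound 3 to compound 4 (0.60 log units; beyond the scatter). For compound 4 the expected result in this assay is 2 mg/kg, estimated to lie between 0.7 mg/kg and 6 mg/kg.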

Compound 4, dose for 50% inhibition: 0.2 mg/kg
Compound 4: middle estimate off by 10-fold (1.00 log units), on the high side, outside the stated range (below it).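

On the core shared by compound 3 and compound 4, methoxy in place of chloro gave a 2.5-fold lower number from compound 3 to compound 4 (0.40 log units; beyond the scatter) in this assay, so less compound was needed for the effect with methoxy on the ring. Compound 2 is known only by a limit of the assay, > 5 mg/kg, and the size of the step that leads to it cannot be read. This series therefore shows that the change can go with a lower number on one core, but it does not show that the change carries over from one core to the other, or that it fails to, and the two instances can be compared no further than this: the same change on two cores in this assay, a number no lower (the limit leaves the size open) from compound 1 to compound 2 and a 2.5-fold lower number (0.40 log units; beyond the scatter) from compound 3 to compound 4; the limit leaves it open whether they differ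

The compounds shown leave open how other groups would behave in the place held by chloro and methoxy, such as an amine, a carboxylic acid or a longer chain like propoxy. No pair shown differs only in the ethoxy group, so what that group adds by itself also remains open.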